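A 4-methylpiperazin-1-yl ring in place of piperidin-1-yl

The source may report more compounds than this note shows. Statements on the series, on what has been measured and on what is new or still open speak of the compounds shown alone.

Measured in a functional assay on HepG2 cells (Homo sapiens) for cytotoxicity, read by MTT assay, with a stated time of 48 h; on this read-out higher numbers stand for weaker inhibition and lower numbers for stronger inhibition:
compound 1 `CC1=NN(C(=O)CN2CCCCC2)C(c2ccccc2O)C1` gives 3020 nM
compound 2 `CC1=NN(C(=O)CN2CCC(c3ccccc3)CC2)C(c2ccccc2O)C1` gives 23300 nM

Of these two numbers, compound 1 has the lower one, 3020 nM, and so shows the stronger inhibition in this assay. The open question is how compound 3 `CC1=NN(C(=O)CN2CCN(C)CC2)C(c2ccccc2O)C1` compares with it. Compound 3 carries 4-methylpiperazin-1-yl in place of piperidin-1-yl on a saturated chain carbon bound to a carbonyl carbon.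

Among the measured compounds shown here, only one measured step bears on this change, and only indirectly. That step is a 7.7-fold higher number from compound 1 to compound 2 (0.89 log units; beyond the scatter), with phenyl in place of hydrogen on a saturated ring carbon. It shows that altering this ring can move the number by a modest amount, and here upward. For the measured compounds named here, no measured compound replaces the piperidin-1-yl ring itself, so the direction remains uncertain. A small rise is expected, which may well stay within the scatter. The expected change is a 1.7-fold higher number from compound 1 to compound 3 (0.22 log units; within the scatter). For compound 3 the estimated value is 5000 nM. The estimated range for compound 3 runs from 1500 nM to 17000 nM.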

Compound 3, half-maximal inhibitory concentration: "not active" (no number reported)
For compound 3 the study gives words and no number; there is nothing to compare the estimate with.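

In this assay, among the compounds shown here, compound 3 is reported only as "not active", with no number, so no step from compound 1 to compound 3 can be read. Nothing shown offers an explanation for this result. The compounds shown leave open how large a number the 4-methylpiperazin-1-yl ring gives on this read-out, compared with compound 1 at 3020 nM in this assay.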